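Replacing a fluoropyridine with a fluoroethoxymethyl on an oxime oxygen

A few compounds are considered here, and "the series" means these few. Any claim that something is new, unique, unknown or untested is made for them only; others in the source may bear on it.

Three compounds share a core built around an oxime oxygen. Compound 1 `Fc1cccc(O/N=C2/C=C(C#Cc3ccccn3)CCC2)n1` carries a 6-fluoropyridin-2-yl on that oxygen, and in an assay on brain (strain Sprague-Dawley) for displacement of a labelled ligand from metabotropic glutamate receptor 5 (Rattus norvegicus), with a stated time of 45 min (a higher number here means a weaker inhibitor, a lower number a stronger inhibitor), compound 1 gives 9.15 nM. Compound 2 `Fc1cccnc1O/N=C1/C=C(C#Cc2ccccn2)CCC1` carries a 3-fluoropyridin-2-yl instead, and in this assay compound 2 gives 4.01 nM, the lowest of the three numbers. Compound 3 `Fc1cccc(O/N=C2\C=C(C#Cc3ccccn3)CCC2)n1` is drawn with the opposite double-bond configuration, and compound 3 gives 44 nM. The change on the oxygen gave a 2.3-fold lower number from compound 1 to compound 2 (0.36 log units; beyond the scatter), while the change in drawn configuration gave a 4.8-fold higher number from compound 1 to compound 3 (0.68 log units; beyond the scatter), a step attributed to the fact that compounds 1 and 3 differ only in the configuration as drawn.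

Compound 4 `FCCOCO/N=C1/C=C(C#Cc2ccccn2)CCC1` is not yet measured. It differs from compound 2 in one place: (2-fluoroethoxy)methyl in place of 3-fluoropyridin-2-yl on an oxygen. Going by the values given here, no measured step replaces an aromatic ring with an open chain here; the nearest precedent, the ring-to-ring swap, was modest. Compound 4 is therefore expected to lose potency, with an estimated step of a 10-fold higher number from compound 2 to compound 4 (1.00 log units; beyond the scatter). The estimate for compound 4 is 40 nM, within a range from 8 nM to 250 nM.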

Compound 4, inhibition constant: 8.41 nM
Beside the measured number, compound 4's estimate is 4.8-fold (0.68 log units) above it; the measured number falls inside the stated range.
By their numbers in this assay, from the lowest: compound 2; then compounds 4 and 1 (each within the scatter of the next); then compound 3.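

The group on the oxime oxygen does not have to be an aromatic ring to give a low number in this assay: the open-chain (2-fluoroethoxy)methyl group gives a 2.1-fold higher number from compound 2 to compound 4 (0.32 log units; beyond the scatter), a modest loss against the better of the two fluoropyridines. Against the other fluoropyridine it gives a 1.1-fold lower number from compound 1 to compound 4 (0.04 log units; within the scatter), so compound 4 cannot be told apart from compound 1, and at this position a ringless chain can do as well as one of the two rings. The information available offers no explanation for this tolerance of an open chain.

On these data alone, it remains open whether a plain propyl chain without fluorine, or a chain carrying an amine, would give a similar number. Also open, as far as these compounds go, is how the (2-fluoroethoxy)methyl group would fare with the opposite double-bond configuration drawn in compound 3.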